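The compounds below may be only part of what the source reports. "The series", "measured", "known", "first", "only" and "open" are said of these compounds alone.

Compound 1 `Oc1cccc(-c2cc(-c3ccccc3F)cc(-c3ccccc3O)n2)c1` gives 35600 nM in a functional assay on DU-145 cells (Homo sapiens) for inhibition; a higher number here means a weaker inhibitor, a lower number a stronger inhibitor.
Compound 2 `Oc1cccc(-c2cc(-c3ccccc3F)cc(-c3cccc(O)c3)n2)c1` gives 11200 nM in this assay.
Compound 3 `Oc1ccc(-c2cc(-c3ccccc3F)cc(-c3cccc(O)c3)n2)cc1` gives 3160 nM in this assay.

Among these three numbers compound 2 stands second highest. Its nearest neighbour is compound 1, and the move between them is a 3.2-fold lower number from compound 1 to compound 2 (0.50 log units; beyond the scatter). Its furthest neighbour is compound 3, reached by a 3.5-fold lower number from compound 2 to compound 3 (0.55 log units; beyond the scatter). Compound 3 also sits below compound 1, by an 11-fold lower number from compound 1 to compound 3 (1.05 log units; beyond the scatter). Every one of these measured steps concerns only where the hydroxyl group sits on one of the outer rings; not one of them alters the fluorophenyl ring.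

Compound 4 `Oc1cccc(-c2cc(-c3ccccc3C(F)(F)F)cc(-c3cccc(O)c3)n2)c1` differs from compound 2 in exactly one place: trifluoromethyl in place of fluoro on an aromatic carbon. Among the compounds with values here, the measured set holds no step that touches this part of the molecule, so there is no direct precedent for how a trifluoromethyl group in place of a fluoro group will behave here. With nothing to point either way, the expectation is a step no larger than the usual scatter, namely a 1.0-fold lower number from compound 2 to compound 4 (0.01 log units; within the scatter), which may turn out in either direction. On that basis compound 4 is estimated to give 11000 nM in this assay, with a plausible range from 3500 nM to 35000 nM.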

Compound 4, half-maximal inhibitory concentration: 2870 nM
For compound 4 the middle estimate is 3.8-fold (0.58 log units) above the measured one; measured number below the stated range.
By their numbers in this assay, from the lowest: compounds 4 and 3 (each within the scatter of the next); then compound 2; then compound 1.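

The earlier steps shown here moved only a hydroxyl group, so they could not show whether the fluoro position matters. In this assay, the change from 2-fluorophenyl to 2-(trifluoromethyl)phenyl gives a 3.9-fold lower number from compound 2 to compound 4 (0.59 log units; beyond the scatter) and so shows that it does: replacing a single fluorine with a group of 4 heavy atoms on this ring carries the number beyond the scatter. This step is similar in size to a 3.5-fold lower number from compound 2 to compound 3 (0.55 log units; beyond the scatter) and also starts from compound 2, so in this small set a change at the fluorinated ring can shift the number about as much as moving a hydroxyl group on an outer ring, although no measurement here explains why the trifluoromethyl group has this effect.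

One pair of compounds cannot show what sets this step's size, and a plain hydrogen, a chlorine, a methyl group, a methoxy group or a nitrile at the same place would help to define the trend. The compounds shown also leave open whether trifluoromethyl would lower the number further if combined with the 4-hydroxyphenyl group of compound 3.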